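Adding a Second Chloro to the Compound with the Highest Number

The compounds below may be only part of what the source reports. "The series", "measured", "known", "first", "only" and "open" are said of these compounds alone.

Compound 1, `Cn1cnc2nc(-c3ccc(Cl)cc3)nn2c1=S`, carries a chloro group on its aromatic ring and, in a functional assay on the whole organism for inhibition, with Rattus norvegicus as the target, at a dose of 3 mg/kg by the intraperitoneal route (on this read-out higher numbers stand for more inhibition at the one dose given (going by the name of the read-out) and lower numbers for less inhibition), compound 1 gives 90%. Two companions share its core and differ only in the halogen on that ring. Compound 2, `Cn1cnc2nc(-c3ccc(F)cc3)nn2c1=S`, gives 38%, and compound 3, `Cn1cnc2nc(-c3ccc(Br)cc3)nn2c1=S`, gives 84%. No number among the three exceeds that of compound 1; compound 3 lies within the usual scatter of it, while compound 2 sits far below. The steps show this directly: a number 52 percentage points lower from compound 1 to compound 2 (beyond the scatter), a number 6 percentage points lower from compound 1 to compound 3 (within the scatter), and a number 46 percentage points higher from compound 2 to compound 3 (beyond the scatter).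

Compound 4, `Cn1cnc2nc(-c3ccc(Cl)c(Cl)c3)nn2c1=S`, keeps the chloro of compound 1 and adds a second one: chloro in place of hydrogen on an aromatic carbon. Among the compounds with values here, no measured step adds a group; each only swaps one halogen for another at a single place. The swap from chloro to bromo left the read-out unchanged within the scatter, and only the swap to fluoro moved it strongly. Since compound 1 already stands near the top of what a percentage can show, little room remains upward, and a second chloro is expected to leave the number close to where it is, so that a number 5 percentage points lower from compound 1 to compound 4 (within the scatter) is expected. Compound 4 is therefore estimated at 85%, within a range of 65% to 98%.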

Compound 4, a percentage reported as inhibition, in the whole organism at one dose (the size of the read-out at that dose, not a potency): 89%
Compound 4: middle estimate off by 4 percentage points, on the low side; the measured number falls inside the stated range.
By their numbers in this assay, from the lowest: compound 2; then compounds 3, 4 and 1 (each within the scatter of the next).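

The earlier compounds shown here only swapped one halogen for another at a single place, whereas this step adds a group at a new place on the aromatic ring, ortho to a chloro group and meta to a large group. In this assay the addition brings a number 1 percentage points lower from compound 1 to compound 4 (within the scatter) and so shows that this carbon can carry a chloro in place of hydrogen with no change that stands out from the scatter, although compound 1 already lies so high on a percentage scale that a gain would have little room to show. Nothing measured here explains this result.

The compounds shown leave open what a methoxy group, an amine or a carboxylic acid on this same carbon would do to the number, and so whether this place accepts groups other than a chloro. They also leave open what a chloro at this place would do on compound 2, whose fluoro starts from a much lower number and would leave more room for a rise to be seen.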